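A few compounds are considered here, and "the series" means these few. Any claim that something is new, unique, unknown or untested is made for them only; others in the source may bear on it.

Compound 3, with the structure `CC(C)[C@H](NC(=O)COc1cccc2ccccc12)C(=O)N[C@@H](CC(=O)O)C(=O)COc1ccccn1`, is the starting point. In a functional assay on Jurkat cells (Homo sapiens) for inhibition (on this read-out lower numbers stand for stronger inhibition and higher numbers for weaker inhibition), compound 3 gives > 200000 nM, and this is a limit of the assay, not a measured number. Its two neighbours share the same core and differ only in the group on the saturated carbon next to the carbonyl. Compound 1, `CC(C)[C@H](NC(=O)COc1cccc2ccccc12)C(=O)N[C@@H](CC(=O)O)C(=O)CSc1nnc(-c2ccccc2)o1`, gives 150000 nM in this assay. Compound 2, `CC(C)[C@H](NC(=O)COc1cccc2ccccc12)C(=O)N[C@@H](CC(=O)O)C(=O)CSc1nnnn1C`, gives > 200000 nM, again a limit rather than a number. The step of an at least 1.3-fold higher number from compound 1 to compound 3 (0.12 log units; that floor lies within the scatter) and the step of an at least 1.3-fold higher number from compound 1 to compound 2 (0.12 log units; that floor lies within the scatter) are therefore only floors, and the step that the two limits leave unreadable from compound 2 to compound 3 cannot be read at all; the reason is the limit of > 200000 nM in this assay, at which 2 of the 3 values shown sit.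

Compound 4, `Cc1cc(OCC(=O)[C@H](CC(=O)O)NC(=O)[C@@H](NC(=O)COc2cccc3ccccc23)C(C)C)nc(C)n1`, carries the change (2,6-dimethylpyrimidin-4-yl in place of pyridin-2-yl on an oxygen on a saturated carbon). Going by the values given here, none of the measured steps alters the aryl group on this oxygen, so they give no direction for it. The expected step is a step that the limit leaves unreadable from compound 3 to compound 4, which means compound 4 is expected to show 250000 nM in this assay, within a range from 100000 nM to 600000 nM, most likely again reported only as a limit.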

Compound 4, half-maximal inhibitory concentration: > 200000 nM
Compound 4: a limit, no number (the forecaster's own chance of this, stated with the estimate: 70%); the middle value lies beyond the limit too.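

In this assay compound 4 gives > 200000 nM, which is a limit of the assay and not a number. Placing 2,6-dimethylpyrimidin-4-yl instead of pyridin-2-yl on this oxygen therefore yields no readable value, and the steps to compound 4 from compound 2 and compound 3 cannot be read, the reason being: the limit of > 200000 nM in this assay, at which 3 of the 4 values shown sit. The only step with any size is an at least 1.3-fold higher number from compound 1 to compound 4 (0.12 log units; that floor lies within the scatter), and it is merely a floor.

Going by these compounds, whether any aryl group on this oxygen can give a measured number remains open, for example a phenyl ring carrying an amine or a carboxylic acid. On these data alone, it is also open whether 5-phenyl-1,3,4-oxadiazol-2-yl would give a number if it were joined through oxygen instead of sulfur.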